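Compound 4: ethoxy in place of hydrogen

The compounds below may be only part of what the source reports. "The series", "measured", "known", "first", "only" and "open" are said of these compounds alone.

The series shares one core: compound 1 is `Nc1cccc(-c2cn3nc(-c4ccc(F)cc4)sc3n2)c1`, compound 2 is `CCc1ccc(-c2nn3cc(-c4cccc(N)c4)nc3s2)cc1`, compound 3 is `Nc1cccc(-c2cn3nc(-c4ccccc4)sc3n2)c1`, and the still unmeasured compound 4 is `CCOc1ccc(-c2nn3cc(-c4cccc(N)c4)nc3s2)cc1`. In a functional assay on L1210 cells (Mus musculus) for inhibition, read by cell counting, with a stated time of 2 days (on this read-out higher numbers stand for weaker inhibition and lower numbers for stronger inhibition), compound 1 returns only a limit, >= 250000 nM. Compound 2 gives 6000 nM in this assay, and compound 3 gives 32000 nM. Of the two numbers, compound 3 sits highest; its nearest neighbour is compound 2, with a 5.3-fold higher number from compound 2 to compound 3 (0.73 log units; beyond the scatter). The other single changes run an at least 41-fold lower number from compound 1 to compound 2 (1.61 log units; beyond the scatter) and an at least 7.8-fold lower number from compound 1 to compound 3 (0.89 log units; beyond the scatter), both starting from the limit (the limit of >= 250000 nM in this assay, at which 1 of the 3 values shown sits).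

Compound 4 differs from compound 3 by ethoxy in place of hydrogen on an aromatic carbon. The step that bears on it is a 5.3-fold higher number from compound 2 to compound 3 (0.73 log units; beyond the scatter), the loss of an ethyl group from the same aromatic carbon; ethoxy now enters there, so a lower number in this assay of comparable size is expected, roughly back to the level of compound 2. For compound 4 the estimate is 8000 nM, within 2500 nM to 30000 nM, which means an expected 4.0-fold lower number from compound 3 to compound 4 (0.60 log units; beyond the scatter).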

Compound 4, half-maximal inhibitory concentration: 155000 nM
Compound 4: middle estimate off by 19-fold (1.29 log units), on the low side; the measured number lies above the stated range.
By their numbers in this assay, from the lowest: compound 2; then compound 3; then compound 4. At a limit, above all of these: compound 1.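

In this assay, ethoxy and ethyl on the same aromatic carbon are not interchangeable, with a 26-fold higher number from compound 2 to compound 4 (1.41 log units; beyond the scatter). Ethoxy also falls behind hydrogen at this position, with a 4.8-fold higher number from compound 3 to compound 4 (0.69 log units; beyond the scatter), so the lower number seen with ethyl does not extend to ethoxy, and a para substituent does not by itself lower the number in this series. Compound 1 remains a limit: the limit of >= 250000 nM in this assay, at which 1 of the 4 values shown sits. Read against that limit, the step is an at least 1.6-fold lower number from compound 1 to compound 4 (0.20 log units; that floor lies within the scatter), and this does not set the pair apart.

From the compounds shown here alone, it remains open whether the oxygen or the chain length separates ethoxy from ethyl, a question on which a methoxy group and a propyl chain on that carbon would bear. Going by these compounds, how an amine or a carboxylic acid would read at the same position also remains open.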